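Bromine on the phenyl arm of a shared core

The source may hold more compounds than are shown below. What is called first, only, known or untested is meant among the compounds shown, and "the series" means these compounds.

Compound 1 `O=C(Cn1c(-c2ccccc2)cc(-c2ccccc2)c1-c1ccco1)Nc1nc2ccccc2s1` and compound 2 `O=C(Cn1c(-c2ccccc2)cc(-c2ccccc2)c1-c1ccccc1)Nc1nc2ccccc2s1` share a core and differ only in one arm, where compound 2 carries phenyl in place of furan-2-yl on an aromatic carbon. In an ADME assay on HEK-293T cells (Homo sapiens) for cytotoxicity, read by MTT assay, with a stated time of 72 h (a higher number here means a weaker inhibitor, a lower number a stronger inhibitor), compound 1 gives < 50000 nM, which is a limit of the assay rather than a number. In this assay compound 2 likewise gives < 50000 nM, again a limit. The step that the two limits leave unreadable from compound 1 to compound 2 therefore cannot be read. Both values sit at the same point (the limit of < 50000 nM in this assay, at which 2 of the 2 values shown sit), so compound 2 stands exactly where compound 1 does, without a numeric position.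

Compound 3 `O=C(Cn1c(-c2ccccc2)cc(-c2ccccc2)c1-c1ccc(Br)cc1)Nc1nc2ccccc2s1` has not yet been tested in this assay. It differs from compound 2 by bromo in place of hydrogen on an aromatic carbon; one bond further out, the same change reads as phenyl to 4-bromophenyl. Going by the values given here, no measured step touches this change, and the one step that exists is unreadable, so no direction of the step from compound 2 to compound 3 can be drawn from the data. The step is estimated as a step that the limit leaves unreadable from compound 2 to compound 3, and the value of compound 3 is expected to be around 20000 nM, between 5000 nM and 50000 nM.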

Compound 3, half-maximal inhibitory concentration: < 50000 nM
Compound 3: no number, only a limit (the forecaster's own chance of this, stated with the estimate: 60%); the middle value does not contradict the limit.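

In this assay compound 3 gives < 50000 nM and this is a limit, not a number. No step among compound 1, compound 2 and compound 3 can be read, since all their values sit at one point: the limit of < 50000 nM in this assay, at which 3 of the 3 values shown sit.

The compounds shown leave open whether furan-2-yl, phenyl and 4-bromophenyl on the shared core differ at all in cytotoxicity.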